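This account rests on a few compounds, and the source may have more. Where it says the series, first, only, none or still open, it means among the compounds named here.

Compound 1 `COc1ccc2c(c1)C/C(=C\c1cc(-c3cc(OC)c(OC)c(OC)c3)n[nH]1)C2=O`: 2000 nM
Compound 2 `COc1cc(-c2cc(/C=C/C(=O)c3ccccc3)[nH]n2)cc(OC)c1OC`: 2300 nM
Compound 3 `COc1ccc(C(=O)/C=C/c2cc(-c3cc(OC)c(OC)c(OC)c3)n[nH]2)cc1`: 950 nM

These three compounds were measured in a functional assay on MDA-MB-231 cells (Homo sapiens) for inhibition, read by MTT assay, with a stated time of 48 h; a lower number here means a stronger inhibitor, a higher number a weaker inhibitor. Compound 3 and compound 2 differ in one place, (hydrogen in place of methoxy on an aromatic carbon), and this step gave a 2.4-fold higher number from compound 3 to compound 2 (0.38 log units; beyond the scatter). Compound 1 and compound 3 have different cores; that difference is not broken down here. Compound 1 and compound 2 give numbers within the scatter of each other.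

The unmeasured compound 4 `COc1cc(-c2cc(/C=C3\Cc4ccccc4C3=O)[nH]n2)cc(OC)c1OC` differs from compound 1 by hydrogen in place of methoxy on an aromatic carbon. This is the same kind of change as from compound 3 to compound 2, but the surroundings differ: there the carbon is para to a large group, here it is part of a fused or bridged system of two rings, meta to a fused ring and para to a fused ring. For compound 4 a step of a 2.3-fold higher number from compound 1 to compound 4 (0.35 log units; beyond the scatter) is expected, because the earlier 2.4-fold higher number from compound 3 to compound 2 (0.38 log units; beyond the scatter) went in that direction. Compound 4 is estimated at 4500 nM, between 2000 nM and 10000 nM.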

Compound 4, half-maximal inhibitory concentration: 7100 nM
For compound 4 the middle estimate is 1.6-fold (0.20 log units) below the measured one; measured number inside the range.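

On the core of compound 1, putting hydrogen in place of methoxy on an aromatic carbon weakened inhibition in this assay and gave a 3.6-fold higher number from compound 1 to compound 4 (0.55 log units; beyond the scatter) on that core. The change went the same way on both cores, and the two steps cannot be told apart in size: the same change on two cores in this assay, a 2.4-fold higher number (0.38 log units; beyond the scatter) from compound 3 to compound 2 and a 3.6-fold higher number (0.55 log units; beyond the scatter) from compound 1 to compound 4, 1.5-fold (0.17 log units) apart, within the scatter of two such steps
In this series, the effect of losing the methoxy therefore carried over between these two cores, but two pairs do not establish a rule for other cores or explain why the effect arises. The compounds shown have only methoxy or hydrogen at this position, so the effect of a hydroxyl group, a fluorine atom or an amine there remains open. On these data alone, whether the same step would appear in other cell lines also remains open.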